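This account rests on a few compounds, and the source may have more. Where it says the series, first, only, none or still open, it means among the compounds named here.

Measured so far in an assay on CHO-K1 cells for displacement of a labelled ligand from prostaglandin E2 receptor EP1 subtype (Homo sapiens); a lower number here means a stronger inhibitor, a higher number a weaker inhibitor:
- compound 1 `Cc1cc(NC(=O)OCc2ccccc2)nn1Cc1cc(Cl)ccc1OCc1ccccc1` gives 79.4 nM
- compound 2 `Cc1cc(NC(=O)OCC(C)C)nn1Cc1cc(Cl)ccc1OCc1ccccc1` gives 25.1 nM

Going by the values given here, compound 2 holds the lower of the two numbers in this assay, the single known step being a 3.2-fold lower number from compound 1 to compound 2 (0.50 log units; beyond the scatter). Compound 3 `Cc1cc(NC(=O)O[C@H]2CCOC2)nn1Cc1cc(Cl)ccc1OCc1ccccc1` differs from compound 2 in one place: oxolan-3-yl in place of isobutyl on an oxygen next to a carbonyl group. That one measured step concerns the same oxygen, yet it traded a phenyl for an isopropyl and says nothing about a saturated ring carrying an oxygen. A step of no more than the scatter is therefore expected, a 1.3-fold higher number from compound 2 to compound 3 (0.11 log units; within the scatter). For compound 3 the estimate is 32 nM, with a range from 10 nM to 100 nM.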

Compound 3, half-maximal inhibitory concentration: 79.4 nM
For compound 3 the middle estimate is 2.5-fold (0.39 log units) below the measured one; measured number inside the range.
By their numbers in this assay, from the lowest: compound 2; then compounds 1 and 3 (each within the scatter of the next).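

On this oxygen next to a carbonyl group, oxolan-3-yl gives up what isobutyl gained, with a 3.2-fold higher number from compound 2 to compound 3 (0.50 log units; beyond the scatter) in this assay. Against benzyl, the same ring shows no change at the digits printed from compound 1 to compound 3 (within the scatter), so among these three groups only isobutyl stands apart. No measured evidence accounts for this difference. The compounds shown leave open whether a cyclopentyl ring, which lacks the ring oxygen, would read like isobutyl or like oxolan-3-yl. They also leave open whether the opposite configuration of the oxolan-3-yl stereocentre would change the number.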